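The compounds below may be only part of what the source reports. "The series", "measured", "known", "first", "only" and "open" are said of these compounds alone.

Measured so far:
Compound 1, `O=C(Nc1ccccc1O)C1CCc2ccccc2N1C(=O)c1ccc(Cl)cc1`: 19200 nM
Compound 2, `O=C(Nc1ccccc1O)C1CCc2ccccc2N1`: 2230 nM

Both were tested in a functional assay on NCI-H23 cells (Homo sapiens) for cytotoxicity, read by sulforhodamine B assay, with a stated time of 72 h; on this read-out lower numbers stand for stronger inhibition of growth and higher numbers for weaker inhibition of growth. Compound 2 gives the lowest of the two numbers, and its nearest neighbour is compound 1, measured at 19200 nM. The step of an 8.6-fold lower number from compound 1 to compound 2 (0.93 log units; beyond the scatter) is the only one in hand, and it is a modest move beyond the scatter: removing the aryl carbonyl from the ring nitrogen lowers the number.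

Compound 3 is `O=C(Nc1ccccc1O)C1CCc2ccccc2N1C(=O)c1cccc(Cl)c1`. It differs from compound 2 by (3-chlorophenyl)carbonyl in place of hydrogen on a nitrogen on an aromatic ring in a ring. This is close to the reverse of the step just seen, with the chlorine moved to another position on the attached ring. Since the same kind of addition raised the number in the step of an 8.6-fold lower number from compound 1 to compound 2 (0.93 log units; beyond the scatter) read backwards, a similar rise beyond the scatter is expected for compound 3, so the estimated step is a 6.7-fold higher number from compound 2 to compound 3 (0.83 log units; beyond the scatter). Compound 3 is therefore expected to give about 15000 nM in this assay, within a range of 5000 nM to 45000 nM.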

Compound 3, concentration for 50% growth inhibition: 11600 nM
Beside the measured number, compound 3's estimate is 1.3-fold (0.11 log units) above it; the range from low to high includes it.
By their numbers in this assay, from the lowest: compound 2; then compounds 3 and 1 (each within the scatter of the next).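

Putting (3-chlorophenyl)carbonyl in place of hydrogen on the ring nitrogen gives a 5.2-fold higher number from compound 2 to compound 3 (0.72 log units; beyond the scatter) in this assay and so repeats, with a second chlorophenyl group, the link seen so far between a free nitrogen and the lower number. Changing only the chlorine's place, with 3-chlorophenyl in place of 4-chlorophenyl on the carbonyl carbon, gives a 1.7-fold lower number from compound 1 to compound 3 (0.22 log units; within the scatter) and so leaves these two chlorine placements indistinguishable in this assay. Nothing available explains the difference between the free and the substituted nitrogen.

The compounds shown leave open whether the higher number goes with the carbonyl or with the chlorophenyl ring, which an acetyl group or a simple methyl on the same nitrogen would help separate. Also open, going by these compounds, is how a 2-chlorophenyl or an unsubstituted phenyl group on the carbonyl would compare.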